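The source may hold more compounds than are shown below. What is called first, only, known or untested is meant among the compounds shown, and "the series" means these compounds.

Of the compounds shown here, three have so far been tested in a functional assay on B16 cells (Mus musculus) for cytotoxicity, read by MTT assay, with a stated time of 48 h; on this read-out lower numbers stand for stronger inhibition and higher numbers for weaker inhibition. Compound 1 `Cc1ccc(-c2cn(CCCO)nn2)cc1` gives > 100000 nM in this assay, and that value is a limit of the assay rather than a number. Compound 2 `Cc1ccc(-c2cn(Cc3ccccc3)nn2)cc1` gives > 100000 nM in this assay, which is again a limit rather than a number. Compound 3 `c1ccc(Cn2cc(-c3ccc4ccccc4c3)nn2)cc1` is the only one of the three with a measured number: in this assay compound 3 gives 3890 nM.

Compounds 1 and 2 differ in a single place: 2-hydroxyethyl in place of phenyl on a saturated chain carbon bound to an aromatic nitrogen. The step that the two limits leave unreadable from compound 2 to compound 1 cannot be read, because of the limit of > 100000 nM in this assay, at which 2 of the 3 values shown sit. How the core of compound 3 differs from the core of compound 2 is not broken down here.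

Compound 4 `OCCCn1cc(-c2ccc3ccccc3c2)nn1` has not yet been measured. It differs from compound 3 by the same change that separates compound 2 from compound 1: 2-hydroxyethyl in place of phenyl on a saturated chain carbon bound to an aromatic nitrogen. Among the compounds with values here, the one measured instance of this change gives no readable size, so there is no measured step on which to lean, and the expectation for compound 4 rests only on compound 3 with its 3890 nM as the starting point. The estimate is therefore wide. Compound 4 is expected to give about 20000 nM in this assay, with an expected range from 3000 nM to 100000 nM. This estimate corresponds to an expected step of a 5.1-fold higher number from compound 3 to compound 4 (0.71 log units; beyond the scatter), and a reported limit instead of a number is a real possibility.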

Compound 4, half-maximal inhibitory concentration: > 100000 nM
Compound 4: only a limit was reported (the forecaster's own chance of this, stated with the estimate: 40%); middle value at least 5.0-fold (0.69 log units) from the limit.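

In this assay, the change from benzyl to 3-hydroxypropyl brings an at least 25-fold higher number from compound 3 to compound 4 (1.41 log units; beyond the scatter), a large step that lies beyond the scatter of repeated measurements. Compound 4 gives > 100000 nM, which is a limit of the assay and not a number, so the printed step is a lower bound on the real difference. This shows that on the core of compound 3 the change removes the only measured potency in the set, but it does not show that the change acts alike on both cores, and the step on the other core cannot be read or set against this one because too many values sit at the same limit: the limit of > 100000 nM in this assay, at which 3 of the 4 values shown sit.

The compounds shown leave open whether the drop goes with losing the phenyl ring or with bringing in the hydroxyl group, and a plain propyl chain, which carries neither, would help to separate the two. They also leave open whether any other group in this place on the core of compound 3, such as a longer chain or a chain ending in an amine or a carboxylic acid, would give a measurable number.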